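The compounds below may be only part of what the source reports. "The series", "measured", "known", "first", "only" and "open" are said of these compounds alone.

Measured in a functional assay on MCF7 cells (Homo sapiens) for antiproliferative activity, read by MTT assay, with a stated time of 72 h; on this read-out lower numbers stand for stronger inhibition and higher numbers for weaker inhibition:
- Compound 1 `CN(c1ccccc1)S(=O)(=O)C1CC2OC1C(c1ccc(NC(=O)CCCCCCC(=O)O)cc1)=C2c1ccc(O)cc1`: 63800 nM
- Compound 2 `Cc1cccc(N(C)S(=O)(=O)C2CC3OC2C(c2ccc(NC(=O)CCCCCCC(=O)O)cc2)=C3c2ccc(O)cc2)c1`: 30200 nM
- Compound 3 `CN(c1ccccc1Cl)S(=O)(=O)C1CC2OC1C(c1ccc(NC(=O)CCCCCCC(=O)O)cc1)=C2c1ccc(O)cc1`: 12800 nM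

Compound 3 has the lowest number of the three, and both of its gaps to the others lie beyond the scatter. Compound 4 `CN(c1ccc(Cl)cc1)S(=O)(=O)C1CC2OC1C(c1ccc(NC(=O)CCCCCCC(=O)O)cc1)=C2c1ccc(O)cc1` has 4-chlorophenyl in place of 2-chlorophenyl on a sulfonamide nitrogen. Going by the values given here, no measured pair shows this exact swap. The closest evidence is chloro in place of hydrogen on an aromatic carbon, which gave a 5.0-fold lower number from compound 1 to compound 3 (0.70 log units; beyond the scatter). Methyl in place of hydrogen gave a smaller change, a 2.1-fold lower number from compound 1 to compound 2 (0.32 log units; beyond the scatter), so the aryl substituents tested so far both lowered the number. On these data alone, whether 4-chlorophenyl keeps all of the chloro gain is unknown, so a modest loss seems likely. The expected change in this assay is a 1.6-fold higher number from compound 3 to compound 4 (0.19 log units; within the scatter). For compound 4 the estimate is 20000 nM, with an expected range of 9000 nM to 45000 nM.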

Compound 4, half-maximal inhibitory concentration: 13700 nM
Beside the measured number, compound 4's estimate is 1.5-fold (0.16 log units) above it, within the range that was stated.
By their numbers in this assay, from the lowest: compounds 3 and 4 (each within the scatter of the next); then compound 2; then compound 1.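

In this assay, 4-chlorophenyl in place of 2-chlorophenyl on the sulfonamide nitrogen gives a 1.1-fold higher number from compound 3 to compound 4 (0.03 log units; within the scatter) and so does not separate the two chlorinated compounds. The gain from chloro in place of hydrogen therefore also appears with 4-chlorophenyl, as a 4.7-fold lower number from compound 1 to compound 4 (0.67 log units; beyond the scatter) shows, while 4-chlorophenyl in place of 3-methylphenyl gives a 2.2-fold lower number from compound 2 to compound 4 (0.34 log units; beyond the scatter) as its step. Nothing measured here offers an explanation for these numbers. Still open, on these data alone, is how 3-chlorophenyl, 4-bromophenyl or 4-methoxyphenyl on this nitrogen would compare with compound 3 and compound 4.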